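Chloro to cyano at an unreadable dose ceiling

The source may report more compounds than this note shows. Statements on the series, on what has been measured and on what is new or still open speak of the compounds shown alone.

compound 1 `O=C1NC(=O)N(/N=C/c2ccc(-c3ccc([N+](=O)[O-])cc3)o2)C1O` — > 1000 mg/kg
compound 2 `O=C1NC(=O)N(/N=C/c2ccc(-c3ccc(Cl)cc3)o2)C1O` — > 1000 mg/kg

In a functional assay on the whole organism for activation, with Mus musculus as the target, with a stated time of 60 min (on this read-out higher numbers stand for an effect only at larger amounts of compound and lower numbers for an effect already at smaller amounts), compound 1 gives only the limit > 1000 mg/kg. In this assay compound 2 also gives only the limit > 1000 mg/kg. The step that the two limits leave unreadable from compound 1 to compound 2 is therefore unreadable, as the limit of > 1000 mg/kg in this assay, at which 2 of the 2 values shown sit, shows both values sitting at that limit. Compound 3 `N#Cc1ccc(-c2ccc(/C=N/N3C(=O)NC(=O)C3O)o2)cc1` differs from compound 2 by cyano in place of chloro on an aromatic carbon. Going by the values given here, no measured step offers a readable size, so no change beyond the scatter is expected, and the limit may well be reported again. The expected step is a number no higher from compound 2 to compound 3 (the limit leaves the size open). Compound 3 is estimated at 1000 mg/kg, within 400 mg/kg to 3000 mg/kg.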

Compound 3, dose for half-maximal effect: > 1000 mg/kg
Compound 3: a limit, no number; the forecaster's own chance of this, stated with the estimate: 80%; the middle value lies on the limit itself.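

In this assay compound 3 gives > 1000 mg/kg, a limit and not a number, and its steps from compound 1 and compound 2 cannot be read. The compounds shown leave open how nitro, chloro and cyano compare in this assay.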